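A few compounds are considered here, and "the series" means these few. Any claim that something is new, unique, unknown or untested is made for them only; others in the source may bear on it.

Measured compounds in a functional assay on K562 cells (Homo sapiens), read by MTT assay, with a stated time of 72 h; on this read-out higher numbers stand for weaker inhibition and lower numbers for stronger inhibition:
Compound 1 `CNc1ncnc2c1c(-c1ccsc1)cn2[C@@H]1O[C@H](CO)[C@@H](O)[C@H]1O` gives > 20000 nM; this is a limit of the assay, not a number.
Compound 2 `CSc1ncnc2c1c(-c1ccsc1)cn2[C@@H]1O[C@H](CO)[C@@H](O)[C@H]1O` gives 450 nM.

On these data alone, compound 1 stands only at a bound: its result is the limit of > 20000 nM in this assay, at which 1 of the 2 values shown sits, so where its true value lies beyond that bound is unknown. Going by the values given here, the single measured step is an at least 44-fold lower number from compound 1 to compound 2 (1.64 log units; beyond the scatter), an exchange at the aromatic carbon carrying methylamino, with thiophen-3-yl kept in place.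

Compound 3 `C#Cc1cn([C@@H]2O[C@H](CO)[C@@H](O)[C@H]2O)c2ncnc(NC)c12` is not yet measured. It differs from compound 1 by ethynyl in place of thiophen-3-yl on an aromatic carbon. Among the compounds with values here, the one measured step alters a different group and so gives no direct guide to this exchange; no step on the five-membered ring substituent has been measured. Since compound 1 itself sits at the limit, compound 3 is expected to remain weak in this assay, and the assay may again report only a limit. Compound 3 is estimated at 20000 nM, with a range from 5000 nM to 80000 nM. That estimate corresponds to an expected step of a number no higher from compound 1 to compound 3 (the limit leaves the size open).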

Compound 3, half-maximal inhibitory concentration: > 20000 nM
Compound 3 gave a limit, no number; the forecaster's own chance of this, stated with the estimate: 60%; the middle value lies on the limit itself.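

Compound 1 and compound 3 both stand only at a limit, not at a number, so the step between them cannot be read: the limit of > 20000 nM in this assay, at which 2 of the 3 values shown sit.

The compounds shown leave open how ethynyl and thiophen-3-yl compare in this assay, and how ethynyl would fare with methylsulfanyl in place of methylamino.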